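Cytotoxicity notes on the shared core series

A few compounds are considered here, and "the series" means these few. Any claim that something is new, unique, unknown or untested is made for them only; others in the source may bear on it.

Measured so far:
compound 1 `COc1ccc2c(c1)[C@@H](O)CN(C)C2` — in an ADME assay on Vero cells (Chlorocebus sabaeus) for cytotoxicity, read by sulforhodamine B assay, with a stated time of 72 h (on this read-out higher numbers stand for weaker inhibition and lower numbers for stronger inhibition), compound 1 gives > 100000 nM
compound 2 `CN1Cc2ccc(OCCC3CCCCC3)cc2[C@@H](O)C1` — in this assay compound 2 gives > 50000 nM

The value of compound 2 is a limit of the assay, not a number. The value of compound 1 is likewise a limit. The step that the two limits leave unreadable from compound 1 to compound 2 is therefore unreadable; the two limits are the limit of > 100000 nM in this assay, at which 1 of the 2 values shown sits, and (the limit of > 50000 nM in this assay, at which 1 of the 2 values shown sits).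

Compound 3 `CN1Cc2ccc(OCc3cccnc3)cc2[C@@H](O)C1` carries pyridin-3-yl in place of cyclohexylmethyl on a saturated chain carbon bound to an oxygen on an aromatic ring. Within the data shown here, the only measured step at this place is unreadable, so no direction beyond the scatter is expected in this assay. Compound 3 is expected to sit at 100000 nM, within 30000 nM to 300000 nM, most likely again as a limit. The expected step that the limit leaves unreadable from compound 2 to compound 3 is none beyond the scatter.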

Compound 3, half-maximal inhibitory concentration: > 50000 nM
Compound 3: no number, only a limit (the forecaster's own chance of this, stated with the estimate: 85%); the middle value lies beyond the limit too.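

Among these compounds, compound 3 gives only a limit, as do compound 1 and compound 2, so no step among them can be read in this assay. The compounds shown leave open whether pyridin-3-yl and cyclohexylmethyl differ at all here.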